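Shortening the butyl chain of compound 2

The source may hold more compounds than are shown below. What is called first, only, known or untested is meant among the compounds shown, and "the series" means these compounds.

Of the compounds shown here, two built on one shared core have been measured in a functional assay on the whole organism for inhibition, with Mus musculus as the target; on this read-out lower numbers stand for an effect already at smaller amounts and higher numbers for an effect only at larger amounts of compound. Compound 1 `CCCCSc1nsnc1C1CN2CCC[C@H]1C2` gives 0.045 mg/kg in that read-out, and compound 2 `CCCCSc1nsnc1[C@@H]1CN2CCC[C@H]1C2` gives 0.026 mg/kg. For the measured compounds named here, the single step between them, a 1.7-fold lower number from compound 1 to compound 2 (0.24 log units; within the scatter), involves no change of atoms or bonds; it rests only on (the fact that one of compounds 1 and 2 is drawn with a defined configuration and the other without, at the place where they differ). Compound 2 thus holds the smaller of the two numbers, yet the gap to compound 1 lies within the scatter, so the two cannot be told apart.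

Compound 3 `CCCSc1nsnc1[C@@H]1CN2CCC[C@H]1C2` is not yet measured. It differs from compound 2 by hydrogen in place of methyl on a saturated chain carbon, three bonds along the chain from a sulfur. Going by the values given here, no measured step touches the butyl chain: the one step available, from an undrawn to a drawn configuration, says nothing about what a shorter chain does. With nothing to lean on, the expectation for compound 3 in this assay is a number close to that of compound 2, a step of a 1.3-fold higher number from compound 2 to compound 3 (0.13 log units; within the scatter) that is not expected to exceed the scatter. The estimate for compound 3 is therefore 0.035 mg/kg, with a range from 0.012 mg/kg to 0.1 mg/kg.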

Compound 3, dose for half-maximal effect: 0.17 mg/kg
Beside the measured number, compound 3's estimate is 4.9-fold (0.69 log units) below it, and the stated range ends below it.
By their numbers in this assay, from the lowest: compounds 2 and 1 (each within the scatter of the next); then compound 3.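

Within this assay, the butyl chain turns out to be sensitive to its length: going from butyl to propyl gives a 6.5-fold higher number from compound 2 to compound 3 (0.82 log units; beyond the scatter), a clear move toward needing a larger dose. For the compounds shown here, this is the first step to lie beyond the scatter and the first to touch the chain, so it shows what the earlier pair, which differ only in a drawn configuration, could not: hydrogen in place of methyl at this one saturated chain carbon, three bonds along the chain from a sulfur, is enough to change the number in this whole-organism read-out. Nothing given here bears on why the shorter chain behaves this way, so the step stands as an observation only.

A single step does not show whether an ethyl or methyl group on the sulfur would raise the number further, or whether a longer chain such as pentyl or hexyl would lower it or raise it relative to compound 2. It also leaves open how the butyl chain would fare with an ether oxygen in place of the sulfur.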